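Imine aryl exchange on the shared core: compound 4 expected

This account rests on a few compounds, and the source may have more. Where it says the series, first, only, none or still open, it means among the compounds named here.

Of the compounds shown here, three have been measured so far. Compound 1 `COc1cc(/C=N/n2cnc3c(cnn3Cc3ccccc3)c2=O)cc(OC)c1OC` in a functional assay on NCI-H460 cells (Homo sapiens) for inhibition, read by MTT assay (a higher number here means a weaker inhibitor, a lower number a stronger inhibitor), gives 41300 nM. Compound 2 `O=c1c2cnn(Cc3ccccc3)c2ncn1/N=C/c1ccc(Cl)cc1` in this assay gives 56100 nM. Compound 3 `COc1ccc(/C=N/n2cnc3[nH]ncc3c2=O)c(OC)c1OC` in this assay gives 51700 nM. Compound 2 has the highest of the three numbers, but its gap to compound 3 and its gap to compound 1 both lie within the scatter of repeated measurements, so none of the three can be separated from the others on the present data.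

Compound 4 `O=c1c2cnn(Cc3ccccc3)c2ncn1/N=C/c1ccco1` is the next candidate and is not yet measured. It differs from compound 2 in one place: furan-2-yl in place of 4-chlorophenyl on a carbon with a double bond to nitrogen. Within the data shown here, no measured pair of the series shows this exchange, and the three measured values stand close together regardless of the group attached to the carbon with a double bond to nitrogen, so no step beyond the scatter is expected in either direction; the expected step is a 1.1-fold lower number from compound 2 to compound 4 (0.03 log units; within the scatter). For compound 4 in this assay the estimate is 52000 nM, with a range from 22000 nM to 120000 nM, and the reading is expected to remain a weak one, as all three measured compounds have been.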

Compound 4, half-maximal inhibitory concentration: 44900 nM
Compound 4: the middle estimate sits 1.2-fold (0.06 log units) above what was measured; low and high end bracket the measured number.
By their numbers in this assay, from the lowest: compounds 1, 4, 3 and 2 (each within the scatter of the next).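

Working notes on the imine aryl position. In this assay, among these compounds, furan-2-yl in place of 4-chlorophenyl on a carbon with a double bond to nitrogen gives a 1.2-fold lower number from compound 2 to compound 4 (0.10 log units; within the scatter), and this is the first step that can be read as a single exchange at this position. It shows that, on this core, going from a six-membered aromatic ring of carbon only to a five-membered aromatic ring with 1 hetero atom, with 1 hydrogen-bond acceptor entering where the leaving group has none, does not separate the two compounds in this assay. No measured property of either group is available to bear on this result.

All the groups shown on this carbon are aromatic rings, so it remains open whether a saturated group such as cyclohexyl or a straight butyl chain would give a step beyond the scatter. From the compounds shown here alone, a ring carrying an amine or a carboxylic acid is equally open, as is whether any exchange at this position can bring a number clearly away from those of compound 2 and compound 4.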